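The source may hold more compounds than are shown below. What is called first, only, known or untested is meant among the compounds shown, and "the series" means these compounds.

In a functional assay on K562 cells (Homo sapiens) for inhibition, read by trypan blue exclusion, with a stated time of 24 h, tested at 10 uM (on this read-out higher numbers stand for more inhibition of growth at the one concentration tested and lower numbers for less inhibition of growth), two compounds have so far been measured. Compound 1 (`Cc1ccccc1OCC(=O)Nc1ccccc1C(N)=O`) gives 19.7%, while compound 2 (`COc1ccc(NC(=O)COc2ccccc2)c(C(N)=O)c1`) gives 85.3%. Compound 2 therefore stands as the higher of the two, and its gap to compound 1 lies beyond the usual scatter.

Compound 3 (`COc1ccc(NC(=O)COc2ccccc2C)c(C(N)=O)c1`) takes compound 2 as its starting point, with methyl in place of hydrogen on an aromatic carbon, ortho to a large group, turning phenyl into 2-methylphenyl: methyl in place of hydrogen on an aromatic carbon. For the measured compounds named here, no measured pair differs in one place only, so this change has not been seen on its own. The 2-methylphenyl group does occur in compound 1 at 19.7%, but two values alone cannot show how much of the gap belongs to that group. A moderate fall in this assay is therefore expected, one that may or may not clear the scatter, rather than a full drop to the lower value. The expected size of the change is a number 17.3 percentage points lower from compound 2 to compound 3 (beyond the scatter). For compound 3 the estimated value is 68%, with an expected range from 40% to 90%.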

Compound 3, percent growth inhibition at one concentration: 40.1%
Estimate against measurement, compound 3: 27.9 percentage points above, within the range that was stated.
By their numbers in this assay, from the lowest: compound 1; then compound 3; then compound 2.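

In this assay, for the compounds shown here, the step of a number 45.2 percentage points lower from compound 2 to compound 3 (beyond the scatter) gives the first reading of this change on its own: methyl in place of hydrogen on an aromatic carbon, ortho to a large group, turning phenyl into 2-methylphenyl, costs a large part of the number. With 2-methylphenyl held fixed, the step of a number 20.4 percentage points higher from compound 1 to compound 3 (beyond the scatter) reads a second change, the addition of a methoxy group to an aromatic carbon that otherwise bears hydrogen, and that step is modest. The two changes therefore each move the number beyond the scatter on their own, methyl downward and methoxy upward, and the presence of 2-methylphenyl does not remove all of the effect of methoxy.

From the compounds shown here alone, it remains open whether the fall belongs to methyl itself or would also follow from another group on the same aromatic carbon, such as fluorine, chlorine, ethyl or an amine, and whether methyl placed elsewhere on that ring would do the same. Nothing at hand accounts for the size or the direction of either step.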